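This account rests on a few compounds, and the source may have more. Where it says the series, first, only, none or still open, it means among the compounds named here.

Measured compounds:
Compound 1 `CCOC(=O)Cn1c(=O)n(C2OC(CO)[C@@H](O)[C@H]2O)c2nc(N)nc(O)c21`, 86%
Compound 2 `CCn1c(=O)n(C2OC(CO)[C@@H](O)[C@H]2O)c2nc(N)nc(O)c21`, 82%

Both compounds were tested in a functional assay on the whole organism (B cells) with Mus musculus as the target; on this read-out lower numbers stand for smaller maximal responses and higher numbers for larger maximal responses. Compound 1 gives 86%, and compound 2 gives 82%. For the measured compounds named here, the one step between them, methyl in place of ethoxycarbonyl on a saturated chain carbon bound to an aromatic nitrogen, amounts to a number 4 percentage points lower from compound 1 to compound 2 (within the scatter), so compound 2 stands within the scatter of compound 1, its only measured neighbour.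

Compound 3 `Nc1nc(O)c2c(n1)n(C1OC(CO)[C@@H](O)[C@H]1O)c(=O)n2Cc1ccccc1` has not yet been measured. It differs from compound 2 as follows: phenyl in place of methyl on a saturated chain carbon bound to an aromatic nitrogen. Going by the values given here, the only measured step, a number 4 percentage points lower from compound 1 to compound 2 (within the scatter), touches the same saturated chain carbon but exchanges a different pair of groups, and it stayed within the scatter. Among the compounds with values here, no step brings a phenyl in at this place, so the data give no direction for the change. Compound 3 is therefore expected to lie near compound 2, with a step of a number 2 percentage points lower from compound 2 to compound 3 (within the scatter), estimated at 80% within a range of 62% to 96%.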

Compound 3, largest response reached (reported as maximal response), in percent of the reference or control that the assay uses: 110%
The estimate for compound 3 lay 30 percentage points below the measured number, outside the stated range (above it).
By their numbers in this assay, from the lowest: compounds 2 and 1 (each within the scatter of the next); then compound 3.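

In this assay, the saturated chain carbon bound to an aromatic nitrogen turns out to be a place where an exchange can move the number beyond the scatter: phenyl in place of methyl gives a number 28 percentage points higher from compound 2 to compound 3 (beyond the scatter), and phenyl in place of ethoxycarbonyl gives a number 24 percentage points higher from compound 1 to compound 3 (beyond the scatter). Among these three compounds, only the entry of phenyl, with its one six-membered aromatic ring of carbon only, sets a compound apart, whereas a number 4 percentage points lower from compound 1 to compound 2 (within the scatter) stayed within the scatter. Nothing available explains why this exchange goes with a larger maximal response.

The compounds shown leave open whether the rise goes with the aromatic ring itself or with the added heavy atoms, which a cyclohexyl group or a longer chain at this place would help to separate. They also leave open how a phenyl carrying a further group, such as a methoxy or an amine, would read.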